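The compounds below may be only part of what the source reports. "The series", "measured", "known", "first", "only" and "open" are said of these compounds alone.

Measured so far:
- compound 1 `Sc1nccn1Cc1cccs1`: 4800 nM
- compound 2 `Sc1nccn1Cc1ccc(Cl)s1`: 1000 nM

Both numbers come from an assay on isolated protein for inhibition of Dopamine beta-hydroxylase (Bos taurus); on this read-out lower numbers stand for stronger inhibition and higher numbers for weaker inhibition. Within the data shown here, compound 1 holds the highest of the two numbers; the only neighbour is compound 2, reached by a 4.8-fold lower number from compound 1 to compound 2 (0.68 log units; beyond the scatter), a chloro in place of hydrogen on an aromatic carbon.

Compound 3 `Fc1ccc(Cn2ccnc2S)s1` differs from compound 1 by fluoro in place of hydrogen on an aromatic carbon. Among the measured compounds shown here, the single step that bears on it is the one from compound 1 to compound 2, a different halogen at the same aromatic carbon. For compound 3 a smaller lowering of the number is therefore expected, estimated as a 1.9-fold lower number from compound 1 to compound 3 (0.28 log units; within the scatter). Compound 3 is estimated at 2500 nM, range 1200 nM to 5500 nM.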

Compound 3, half-maximal inhibitory concentration: 4600 nM
Beside the measured number, compound 3's estimate is 1.8-fold (0.26 log units) below it; the measured number falls inside the stated range.
By their numbers in this assay, from the lowest: compound 2; then compounds 3 and 1 (each within the scatter of the next).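

Fluoro in place of hydrogen at this aromatic carbon, next to the ring sulfur, gives no step beyond the scatter in this assay (a 1.0-fold lower number from compound 1 to compound 3 (0.02 log units; within the scatter)), so a halogen here does not by itself carry the lowering seen with chloro. Fluoro and chloro at the same carbon are clearly apart (a 4.6-fold higher number from compound 2 to compound 3 (0.66 log units; beyond the scatter)), and among the groups shown only chloro lowers the number. No measurement on hand accounts for this gap between the two halogens.

As far as these compounds go, whether bromo, methyl or trifluoromethyl at this carbon would side with chloro or with fluoro stays open. So does whether chloro elsewhere on the ring would give a similar step.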